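The compounds below may be only part of what the source reports. "The series", "measured", "known", "first", "only" and "open" are said of these compounds alone.

- Compound 1 `O=C(/C=C/c1ccc(O)cc1)c1c(O)cccc1OCC1CCCCC1`: > 30000 nM
- Compound 2 `O=C(/C=C/c1ccc(O)cc1)c1c(O)cccc1OCc1ccccc1`: > 30000 nM
- Compound 3 `O=C(/C=C/c1ccc(O)cc1)c1c(O)cccc1OCCC1CCCC1`: not yet measured

In a functional assay on PC-3 cells (Homo sapiens) for antiproliferative activity, read by sulforhodamine B assay (a lower number here means a stronger inhibitor of growth, a higher number a weaker inhibitor of growth), compound 2 gives > 30000 nM, which is a limit and not a number. It shares that position with compound 1: the limit of > 30000 nM in this assay, at which 2 of the 2 values shown sit. Compound 3 differs from compound 2 by cyclopentylmethyl in place of phenyl on a saturated chain carbon bound to an oxygen on an aromatic ring, with cyclopentylmethyl in place of phenyl on a saturated chain carbon bound to an oxygen on an aromatic ring. Within the data shown here, the only measured step at this place, a step that the two limits leave unreadable from compound 1 to compound 2, gives no size to carry over. Among the measured compounds shown here, no step of definite size or direction is therefore expected in this assay. The expected step is a number no higher from compound 2 to compound 3 (the limit leaves the size open). Compound 3 is expected to stay near that limit, at an estimated 30000 nM, within a range of 10000 nM to 60000 nM.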

Compound 3, concentration for 50% growth inhibition: 3480 nM
Beside the measured number, compound 3's estimate is 8.6-fold (0.94 log units) above it; measured number below the stated range.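

In this assay, the change to cyclopentylmethyl at this place, on a saturated chain carbon bound to an oxygen on an aromatic ring, gives an at least 8.6-fold lower number from compound 2 to compound 3 (0.93 log units; beyond the scatter). Set against the cyclohexyl group, it gives an at least 8.6-fold lower number from compound 1 to compound 3 (0.93 log units; beyond the scatter). The position can therefore carry a group that gives a measurable number, and compound 3 alone has one, the others resting at a limit: the limit of > 30000 nM in this assay, at which 2 of the 3 values shown sit.

From the compounds shown here alone, the full size of both steps stays open. So does whether a longer chain or an amine in place of cyclopentylmethyl would lower the number further.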